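A few compounds are considered here, and "the series" means these few. Any claim that something is new, unique, unknown or untested is made for them only; others in the source may bear on it.

Measured in a functional assay on HL-60 cells (Homo sapiens) for antiproliferative activity, read by MTT assay, with a stated time of 48 h; on this read-out higher numbers stand for weaker inhibition and lower numbers for stronger inhibition:
- Compound 1 `CC(=O)OC/C1=C/C[C@](C)(CCC=C(C)C)/C=C/[C@@H](OC(=O)C=C(C)C)[C@](C)(O)/C=C/C1=O`: 2950 nM
- Compound 2 `CC(C)=CCC[C@]1(C)/C=C/[C@@H](OC(=O)C=C(C)C)[C@](C)(O)/C=C/C(=O)/C(C(=O)O)=C\C1`: > 10000 nM, a limit of the assay
- Compound 3 `COCOC/C1=C/C[C@](C)(CCC=C(C)C)/C=C/[C@@H](OC(=O)C=C(C)C)[C@](C)(O)/C=C/C1=O`: 2840 nM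

Compound 3 stands level with compound 1, with a 1.0-fold lower number from compound 1 to compound 3 (0.02 log units; within the scatter). Compound 4 `CC(C)=CCC[C@]1(C)/C=C/[C@@H](OC(=O)C=C(C)C)[C@](C)(O)/C=C/C(=O)/C(C(=O)N(C(C)C)C(C)C)=C\C1` differs from compound 3 at one place: diisopropylcarbamoyl in place of (methoxymethoxy)methyl on a double-bonded ring carbon. This puts diisopropylcarbamoyl in place of (methoxymethoxy)methyl on a double-bonded ring carbon.

Two measured steps at that carbon bear on this change: an at least 3.3-fold higher number from compound 1 to compound 2 (0.53 log units; beyond the scatter) and an at least 3.5-fold lower number from compound 2 to compound 3 (0.54 log units; beyond the scatter), both beyond the scatter. Compound 4 shares a carbonyl on that carbon with compound 2, so part of that size is expected to carry over. A modest rise is therefore expected in this assay, a 1.9-fold higher number from compound 3 to compound 4 (0.29 log units; within the scatter). The estimate for compound 4 is 5500 nM, with an expected range of 2200 nM to 14000 nM.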

Compound 4, half-maximal inhibitory concentration: 12700 nM
The estimate for compound 4 lay 2.3-fold (0.36 log units) below the measured number, and the stated range covers the measured number.
By their numbers in this assay, from the lowest: compounds 3 and 1 (each within the scatter of the next); then compound 4.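

In this assay, replacing the ether or ester side arm on this double-bonded ring carbon with diisopropylcarbamoyl gives a 4.5-fold higher number from compound 3 to compound 4 (0.65 log units; beyond the scatter) and a 4.3-fold higher number from compound 1 to compound 4 (0.63 log units; beyond the scatter), so a carbonyl-bearing amide here also goes with weaker inhibition, not only the carboxy group of compound 2. The step from compound 2 to compound 4 cannot be read, since compound 2 stands at a limit of the assay: the limit of > 10000 nM in this assay, at which 1 of the 4 values shown sits.

The compounds shown leave open whether a smaller dimethylamide or a methyl ester at this carbon would follow compound 4. They also leave open whether a free hydroxymethyl group would stay level with compound 1 and compound 3.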